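The source may hold more compounds than are shown below. What is called first, only, known or untested is meant among the compounds shown, and "the series" means these compounds.

Measured in a functional assay on U-251 cells (Homo sapiens) for antiproliferative activity, read by MTT assay, with a stated time of 24 h; a higher number here means a weaker inhibitor, a lower number a stronger inhibitor:
- Compound 1 `C#CCOc1ccc2c(=O)c(-c3cc(OC)c(OC)cc3OC)coc2c1`: 6450 nM
- Compound 2 `COc1cccc(C(=O)Oc2ccc3c(=O)c(-c4cc(OC)c(OC)cc4OC)coc3c2)c1`: > 10000 nM, a limit of the assay
- Compound 3 `COc1cc(OC)c(-c2coc3cc(OCc4ccccc4F)ccc3c2=O)cc1OC`: 2890 nM

Compound 3 holds the lower of the two true numbers, with a 2.2-fold lower number from compound 1 to compound 3 (0.35 log units; beyond the scatter). Against the limit, the data show an at least 3.4-fold lower number from compound 2 to compound 3 (0.53 log units; beyond the scatter).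

Compound 4 `COc1cc(OC)c(-c2coc3cc(OCc4ccc(Br)cc4)ccc3c2=O)cc1OC` differs from compound 3 as follows: 4-bromophenyl in place of 2-fluorophenyl on a saturated chain carbon bound to an oxygen on an aromatic ring. Here 4-bromophenyl replaces 2-fluorophenyl on a saturated chain carbon bound to an oxygen on an aromatic ring. Both measured steps into compound 3 changed the group on this oxygen, but neither compares two substituted phenyl groups on that chain carbon. No change beyond the scatter is therefore expected in this assay, and the estimated step is a 1.0-fold higher number from compound 3 to compound 4 (0.02 log units; within the scatter). Compound 4 is expected at 3000 nM, within an estimated range of 1200 nM to 7500 nM.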

Compound 4, half-maximal inhibitory concentration: 10000 nM
For compound 4 the middle estimate is 3.3-fold (0.52 log units) below the measured one; measured number outside the range, above it.
By their numbers in this assay, from the lowest: compound 3; then compounds 1 and 4 (each within the scatter of the next).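

In this assay, the saturated chain carbon bound to an oxygen on an aromatic ring now carries two different substituted phenyl groups, and the choice between them matters: 4-bromophenyl in place of 2-fluorophenyl gives a 3.5-fold higher number from compound 3 to compound 4 (0.54 log units; beyond the scatter). With 4-bromophenyl, the gain over ethynyl seen for 2-fluorophenyl is gone, with a 1.6-fold higher number from compound 1 to compound 4 (0.19 log units; within the scatter). The data give only a number no higher from compound 2 to compound 4 (the limit leaves the size open), and that size cannot be read, because the starting value is a limit rather than a number: the limit of > 10000 nM in this assay, at which 1 of the 4 values shown sits.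

The compounds shown do not separate the halogen from where it sits on the phenyl ring, as 4-fluorophenyl or 2-bromophenyl would. On these data alone, how a phenyl group bearing an amine or a carboxylic acid would behave also stays open.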